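Removing a Ring Fluorine from a Guanylate Cyclase Activator

The source may report more compounds than this note shows. Statements on the series, on what has been measured and on what is new or still open speak of the compounds shown alone.

Measured compounds:
compound 1 `COC(=O)N(C)c1c(N)nc(-n2nc(Cc3ccccc3F)c3cc(F)ccc32)nc1N` — 960 nM
compound 2 `Nc1nc(-n2nc(Cc3ccccc3F)c3ccccc32)nc2c1CC(=O)N2` — 160 nM

In an assay on CHO cells for activation of soluble guanylate cyclase alpha1/beta1 complex (Homo sapiens), read by cGMP accumulation (on this read-out higher numbers stand for an effect only at larger amounts of compound and lower numbers for an effect already at smaller amounts), compound 1 gives 960 nM, the higher of the two numbers. Compound 2 gives 160 nM, a lower number that lies beyond the usual scatter; compound 2 differs from compound 1 in more than one place, so nothing about any single group can be read from that pair.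

Compound 3 `COC(=O)N(C)c1c(N)nc(-n2nc(Cc3ccccc3F)c3ccccc32)nc1N` differs from compound 1 by hydrogen in place of fluoro on an aromatic carbon. Within the data shown here, no measured pair shows this change on its own, so its effect in this assay is unknown. The author expects only a small step, within the scatter or slightly toward a lower number, since the change is a single fluorine on the fused carbocyclic ring and the shared core is untouched; the expected step is a 1.4-fold lower number from compound 1 to compound 3 (0.14 log units; within the scatter). Compound 3 is therefore estimated at 700 nM, with a range from 250 nM to 2500 nM.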

Compound 3, half-maximal effective concentration: 310 nM
Compound 3: middle estimate off by 2.3-fold (0.35 log units), on the high side, within the range that was stated.
By their numbers in this assay, from the lowest: compounds 2 and 3 (each within the scatter of the next); then compound 1.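

Replacing fluoro with hydrogen on this aromatic carbon gives, in this assay, a 3.1-fold lower number from compound 1 to compound 3 (0.49 log units; beyond the scatter), a step that lies beyond the usual scatter. This is the first change in one place alone among the compounds shown, so the higher number of compound 1 can now be tied in part to the fluoro on this six-membered aromatic ring, meta to a fused ring and para to a fused ring, although this rests on a single pair. Nothing available explains why the number moves with this change.

From the compounds shown here alone, it remains open whether chloro, methoxy or a nitrile on the same carbon would give a number nearer to that of compound 1 or to that of compound 3. Also open, going by these compounds, is whether hydrogen in place of the fluoro on the other aromatic ring, which compound 1 and compound 3 share, would give a step of similar size.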